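The source may hold more compounds than are shown below. What is called first, only, known or untested is meant among the compounds shown, and "the series" means these compounds.

Three compounds have been measured in an ADME assay on HEK293 cells (Homo sapiens) for cytotoxicity, read by resazurin assay, with a stated time of 48 h (on this read-out higher numbers stand for lower toxicity in this test and lower numbers for higher toxicity in this test), so far:

Compound 1 `COc1ccc(S(=O)(=O)Nc2ccc(-c3nc4cc(NS(=O)(=O)c5ccc(OC)cc5)ccc4o3)cc2)cc1` gives 48000 nM
Compound 2 `COc1ccc(S(=O)(=O)Nc2ccc3oc(-c4ccc(NC(=O)c5ccc(Cl)s5)cc4)nc3c2)cc1` gives 15000 nM
Compound 3 `COc1ccc(S(=O)(=O)Nc2ccc3oc(-c4ccc(NS(=O)(=O)c5cc(Br)ccc5OC)cc4)nc3c2)cc1` gives 18000 nM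

Compound 3 stands with compound 2 in the lower pair of values (a 1.2-fold higher number from compound 2 to compound 3 (0.08 log units; within the scatter)). Compound 4 `COc1ccc(S(=O)(=O)Nc2ccc3oc(-c4ccc(NS(=O)(=O)c5cc(F)ccc5OC)cc4)nc3c2)cc1` has not been measured, and it differs from compound 3 in a single place (fluoro in place of bromo on an aromatic carbon): fluoro in place of bromo on an aromatic carbon. Among the compounds with values here, no measured step makes this swap. The closest guide is modest (a 2.7-fold lower number from compound 1 to compound 3 (0.43 log units; beyond the scatter)), and it brought the bromo group into the same ring. For compound 4 in this assay the expected step is a 1.2-fold higher number from compound 3 to compound 4 (0.09 log units; within the scatter) (no move beyond the scatter). For compound 4 the estimated value is 22000 nM (expected range 11000 nM to 45000 nM).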

Compound 4, half-maximal cytotoxic concentration: 24000 nM
Compound 4: the middle estimate sits 1.1-fold (0.04 log units) below what was measured; measured number inside the range.
By their numbers in this assay, from the lowest: compounds 2, 3, 4 and 1 (each within the scatter of the next, the first and the last beyond it).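

Putting fluoro in place of bromo on this aromatic carbon, para to a methoxy group, gives only a small step in this assay: a 1.3-fold higher number from compound 3 to compound 4 (0.12 log units; within the scatter). The two other steps, a 1.6-fold higher number from compound 2 to compound 4 (0.20 log units; within the scatter) and a 2.0-fold lower number from compound 1 to compound 4 (0.30 log units; within the scatter), also stay within the scatter, whereas the bromo compound, compound 3, lay beyond it from compound 1. Nothing is available to explain these numbers.

From the compounds shown here alone, it remains open whether an amine or a carboxylic acid on this same aromatic carbon would give a step beyond the scatter.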